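The source may report more compounds than this note shows. Statements on the series, on what has been measured and on what is new or still open speak of the compounds shown alone.

Among the compounds with values here, compound 1 `COc1cc(OC)c(/C=C/S(=O)(=O)Cc2ccc(OC)c(OP(=O)(O)O)c2)c(OC)c1` is the stronger of the two compounds measured so far in a functional assay on DLD-1 cells (Homo sapiens) for antiproliferative activity, read by trypan blue exclusion (on this read-out lower numbers stand for stronger inhibition and higher numbers for weaker inhibition), where compound 1 gives 7 nM. Within the data shown here, compound 2 `COc1ccc(CS(=O)(=O)/C=C/c2ccc(F)cc2Cl)cc1` is the only other compound with a number, and in this assay compound 2 gives 4000 nM, far weaker and beyond the scatter. Compound 3 `COc1ccc(CS(=O)(=O)/C=C/c2c(OC)cc(OC)cc2OC)cc1` differs from compound 1 in one place: a hydrogen atom in place of a group of 5 heavy atoms (4 oxygen, 1 phosphorus; no ring), on an aromatic carbon. Among the measured compounds shown here, with no measured pair showing what this change does, a moderate loss of potency is expected, the estimated step being a 4.3-fold higher number from compound 1 to compound 3 (0.63 log units; beyond the scatter). Compound 3 is therefore expected to give about 30 nM, between 5 nM and 200 nM.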

Compound 3, half-maximal inhibitory concentration: 40 nM
The estimate for compound 3 lay 1.3-fold (0.12 log units) below the measured number, and the stated range covers the measured number.
By their numbers in this assay, from the lowest: compound 1; then compound 3; then compound 2.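

Putting a hydrogen atom in place of the group of 5 heavy atoms (4 oxygen, 1 phosphorus) on this aromatic carbon gives a 5.7-fold higher number from compound 1 to compound 3 (0.76 log units; beyond the scatter) in this assay. The change costs potency, yet the step is modest, and compound 3 still gives 40 nM, so that group is not essential for activity here. No evidence on the cause of this step is available. Still open, as far as these compounds go, is how a hydroxyl group or a carboxylic acid on this same carbon would compare with compound 1 and compound 3.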